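Amide-end variation on the shared bis-sulfonyl core

The compounds below may be only part of what the source reports. "The series", "measured", "known", "first", "only" and "open" are said of these compounds alone.

Measured so far:
compound 1, `CCN(CC)S(=O)(=O)c1ccc(S(=O)(=O)N2CCC[C@@H](C(=O)N3CCC(O)CC3)C2)cc1`, 230 nM
compound 2, `CCN(CC)S(=O)(=O)c1ccc(S(=O)(=O)N2CCC[C@@H](C(=O)N3CCC(COC)CC3)C2)cc1`, 50 nM
compound 3, `CCN(CC)S(=O)(=O)c1ccc(S(=O)(=O)N2CCC[C@@H](C(=O)N3CC[C@H](OC)C3)C2)cc1`, 460 nM

In a functional assay on MIA PaCa-2 cells (Homo sapiens) for inhibition, read by MTT assay, with a stated time of 3 days (a higher number here means a weaker inhibitor, a lower number a stronger inhibitor), compound 3 gives the highest of the three numbers. Its nearest neighbour is compound 1, the step being a 2.0-fold higher number from compound 1 to compound 3 (0.30 log units; within the scatter); the step from the lowest number is a 9.2-fold higher number from compound 2 to compound 3 (0.96 log units; beyond the scatter). Within this set the amide end is the only part that varies, and the other variation seen there is a 4.6-fold lower number from compound 1 to compound 2 (0.66 log units; beyond the scatter).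

Compound 4, `CCN(CC)S(=O)(=O)c1ccc(S(=O)(=O)N2CCC[C@@H](C(=O)N[C@H]3CCOC3)C2)cc1`, carries the change ((oxolan-3-yl)amino in place of 3-methoxypyrrolidin-1-yl on a carbonyl carbon). None of the three measured steps covers this kind of exchange: all of them swap one ring bonded through its ring nitrogen for another, whereas here the ring is attached through an amino group. The steps that do exist at the amide end run from within the scatter to modest, so a step of comparable size in either direction is plausible, with no firm pull in one direction. Compound 4 is therefore expected near compound 3, with an estimated step of a 1.3-fold higher number from compound 3 to compound 4 (0.12 log units; within the scatter); the estimate for compound 4 is 600 nM, ranging from 200 nM to 2000 nM.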

Compound 4, half-maximal inhibitory concentration: 290 nM
The estimate for compound 4 lay 2.1-fold (0.32 log units) above the measured number, and the stated range covers the measured number.
By their numbers in this assay, from the lowest: compound 2; then compounds 1, 4 and 3 (each within the scatter of the next).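

In this assay, attaching the ring through an amino group, as (oxolan-3-yl)amino on the carbonyl carbon, brings in a hydrogen-bond donor, yet compound 4 stays within the scatter of both compound 3 and compound 1 (a 1.6-fold lower number from compound 3 to compound 4 (0.20 log units; within the scatter); a 1.3-fold higher number from compound 1 to compound 4 (0.10 log units; within the scatter)). The 4-(methoxymethyl)piperidin-1-yl group remains apart, with a 5.8-fold higher number from compound 2 to compound 4 (0.76 log units; beyond the scatter), so compound 2 now has a step beyond the scatter to each of the other compounds. No evidence bearing on the reason for these values is available.

Still open, going by these compounds, is how a methyl group on the amide nitrogen of compound 4 would read, as that would remove the amide hydrogen while keeping the oxolan-3-yl ring. Also open, on these data alone, is whether an ethoxymethyl group, a longer ether chain or a carboxylic acid on the piperidine ring would match compound 2.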